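The source may hold more compounds than are shown below. What is called first, only, known or untested is meant among the compounds shown, and "the series" means these compounds.

Measured in a functional assay on SK-N-SH cells (Homo sapiens) for cytotoxicity, read by MTT assay, with a stated time of 48 h; on this read-out higher numbers stand for weaker inhibition and lower numbers for stronger inhibition:
compound 1 `COc1ccc(/C=C/c2cc(OC)c(OC)c(OC)c2-c2ccc(OC)cc2)cc1`: 36000 nM
compound 2 `COc1cc(/C=C/c2ccccc2)c(-c2ccccc2)c(OC)c1OC`: 63000 nM
compound 3 `C=C(c1ccc(OC)cc1)c1cc(OC)c(OC)c(OC)c1-c1ccc(OC)cc1`: 75000 nM

In this assay, compound 3 gives 75000 nM. This lies within the scatter of compound 2 and beyond the scatter from compound 1, whose number is lower.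

Compound 4 `C=C(c1ccc(OC)cc1)c1cc(OC)c(OC)c(OC)c1-c1ccc2ccccc2c1` has naphthalen-2-yl in place of 4-methoxyphenyl on an aromatic carbon, ortho to a 1-(4-methoxyphenyl)ethenyl group: naphthalen-2-yl in place of 4-methoxyphenyl on an aromatic carbon.

For the measured compounds named here, the only measured single-place step is a 2.1-fold higher number from compound 1 to compound 3 (0.32 log units; beyond the scatter). It is modest, and it concerns the 1-(4-methoxyphenyl)ethenyl group, not the place changed here. Going by the values given here, no measured step isolates a change at this place, so neither its size nor its direction can be taken from the data. With all three values close together, no step beyond the scatter is expected in this assay. The estimate amounts to a 1.3-fold lower number from compound 3 to compound 4 (0.10 log units; within the scatter), an expected step that should not be read as a direction. Compound 4 is estimated at 60000 nM, with an expected range of 20000 nM to 150000 nM.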

Compound 4, half-maximal inhibitory concentration: 6000 nM
Compound 4: middle estimate off by 10-fold (1.00 log units), on the high side, and the stated range ends above it.
By their numbers in this assay, from the lowest: compound 4; then compounds 1, 2 and 3 (each within the scatter of the next, the first and the last beyond it).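

In this assay, the aromatic carbon ortho to the 1-(4-methoxyphenyl)ethenyl group proves to be a sensitive place: naphthalen-2-yl in place of 4-methoxyphenyl gives a 13-fold lower number from compound 3 to compound 4 (1.10 log units; beyond the scatter) in the read-out. For the compounds shown here, the only earlier single-place step, a 2.1-fold higher number from compound 1 to compound 3 (0.32 log units; beyond the scatter) and modest, concerned the 1-(4-methoxyphenyl)ethenyl group, so this is the first measured change at this place. Nothing measured here accounts for the size of this step.

The change removes a methoxy group and adds a second six-membered aromatic ring in one step, and the compounds shown do not separate the two. Also open, on these data alone, are how an amine or a carboxylic acid on the naphthalen-2-yl group would behave and whether naphthalen-2-yl gives a similar step alongside the 2-(4-methoxyphenyl)ethenyl group of compound 1.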